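This account rests on a few compounds, and the source may have more. Where it says the series, first, only, none or still open, it means among the compounds named here.

In a functional assay on HEK293 cells for antagonist activity at thromboxane A2 receptor (Homo sapiens), read by fluorescence and calcium flux (a higher number here means a weaker inhibitor, a lower number a stronger inhibitor), compound 2 `Cc1ccccc1Nc1ccc(C#N)cc1S(=O)(=O)NC(=O)NC(C)(C)C` gives 4780 nM. Compound 1 `CCCCCNC(=O)NS(=O)(=O)c1cc(C#N)ccc1Oc1ccc(F)cc1` gives 9530 nM in this assay, a number within the usual scatter of that for compound 2, so neither can be called the stronger inhibitor. Compound 3 `CCCCCNC(=O)NS(=O)(=O)c1cc(C#N)ccc1Nc1ccccc1C` has not yet been measured; it differs from compound 2 by pentyl in place of tert-butyl on an amide-type nitrogen. Among the measured compounds shown here, no pair of measured compounds isolates this change, since compound 1 also differs from compound 2 elsewhere, so only a modest shift, if any, is expected. Compound 3 is expected to give about 6000 nM in this assay, within a range from 2000 nM to 18000 nM, a step of a 1.3-fold higher number from compound 2 to compound 3 (0.10 log units; within the scatter) that is expected to stay within the scatter.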

Compound 3, half-maximal inhibitory concentration: 7850 nM
Estimate against measurement, compound 3: 1.3-fold (0.12 log units) below; low and high end bracket the measured number.
By their numbers in this assay, from the lowest: compounds 2, 3 and 1 (each within the scatter of the next).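

Pentyl in place of tert-butyl on an amide-type nitrogen, now seen as a single change, gives a 1.6-fold higher number from compound 2 to compound 3 (0.22 log units; within the scatter) in this assay, so the two groups cannot be told apart here. (2-Methylphenyl)amino in place of 4-fluorophenoxy on an aromatic carbon gives a 1.2-fold lower number from compound 1 to compound 3 (0.08 log units; within the scatter), so that swap cannot be separated from the scatter either. No measured evidence bears on these results. As far as these compounds go, whether a cyclohexyl group or a chain ending in a carboxylic acid on that nitrogen would move the number beyond the scatter stays open.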